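The source may hold more compounds than are shown below. What is called first, only, known or untested is meant among the compounds shown, and "the series" means these compounds.

Among the measured compounds shown here, compound 1 `O=S(=O)(NCCCNCc1ccc(Cl)c(Cl)c1)c1cc(C(F)(F)F)cc(C(F)(F)F)c1` is one of two compounds measured in a functional assay on PANC-1 cells (Homo sapiens) for inhibition, read by MTT assay, with a stated time of 72 h; a lower number here means a stronger inhibitor of growth, a higher number a weaker inhibitor of growth. In this assay compound 1 gives 5600 nM, the lowest of the two numbers. The other, compound 2 `O=S(=O)(NCCCNCc1ccccc1)c1cc(C(F)(F)F)cc(C(F)(F)F)c1`, gives in this assay 16000 nM. For the measured compounds named here, the single step between them, a 2.9-fold higher number from compound 1 to compound 2 (0.46 log units; beyond the scatter), comes from exchanging phenyl for 3,4-dichlorophenyl on a saturated chain carbon bound to an amine nitrogen. Compound 3 `O=S(=O)(NCCCNCc1ccc(Br)cc1)c1cc(C(F)(F)F)cc(C(F)(F)F)c1` has not yet been measured. It differs from compound 1 in one place: 4-bromophenyl in place of 3,4-dichlorophenyl on a saturated chain carbon bound to an amine nitrogen. This change keeps one halogen on the ring where compound 2 keeps none, so the step from compound 1 to compound 2 bears on it, and an increase smaller than that one is expected in this assay. Compound 3 is therefore estimated at 8500 nM, within a range of 4000 nM to 18000 nM. That estimate means a step of a 1.5-fold higher number from compound 1 to compound 3 (0.18 log units; within the scatter), which is expected to lie near the edge of the scatter.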

Compound 3, concentration for 50% growth inhibition: 2200 nM
Compound 3: the middle estimate sits 3.9-fold (0.59 log units) above what was measured; measured number outside the range, below it.
By their numbers in this assay, from the lowest: compound 3; then compound 1; then compound 2.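

In this assay, the change gives a 2.5-fold lower number from compound 1 to compound 3 (0.41 log units; beyond the scatter) even though 4-bromophenyl carries 1 bromine where 3,4-dichlorophenyl carries 2 chlorine, so more halogen on this ring does not go with a lower number among these compounds. Bromo in place of hydrogen on an aromatic carbon gives a 7.3-fold lower number from compound 2 to compound 3 (0.86 log units; beyond the scatter) and places compound 3 lowest of the three, so a single halogen on the ring is enough for a clear drop from the phenyl compound. No measurement shown here explains this order.

The halogen and its ring pattern change together in this step, so a compound with 4-chlorophenyl or 3-bromophenyl would be needed to separate the two. As far as these compounds go, whether 4-methoxyphenyl or a longer chain would keep this order remains open.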